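A few compounds are considered here, and "the series" means these few. Any claim that something is new, unique, unknown or untested is made for them only; others in the source may bear on it.

Compound 1 `O=C(CNc1ccccc1F)N[C@H]1CCOC1=O`: in a functional assay on MCF7 cells (Homo sapiens) for antiproliferative activity, read by MTT assay, with a stated time of 72 h (a higher number here means a weaker inhibitor, a lower number a stronger inhibitor), compound 1 gives > 64000 nM, a limit of the assay.
Compound 2 `O=C(CNc1ccc(Cl)cc1Cl)N[C@H]1CCOC1=O`: in this assay compound 2 gives > 64000 nM, also a limit.
Compound 3 `O=C(CNc1ccccc1)N[C@H]1CCOC1=O`: in this assay compound 3 gives > 64000 nM, again a limit.

Compound 3 therefore stands only at a limit, as do all three values shown (the limit of > 64000 nM in this assay, at which 3 of the 3 values shown sit). Going by the values given here, the one measured step, a step that the two limits leave unreadable from compound 1 to compound 3, cannot be read in size, so no measured step tells how large a change to expect here. Compound 4 `O=C(CNc1ccccc1Cl)N[C@H]1CCOC1=O` differs from compound 3 by chloro in place of hydrogen on an aromatic carbon. Since compound 2, which also carries chloro groups, sits at the limit > 64000 nM, compound 4 is expected to stay there too. The step that the limit leaves unreadable from compound 3 to compound 4 is expected to be none beyond the scatter. Compound 4 is thus estimated at 100000 nM, within 30000 nM to 300000 nM, most likely reported only as a limit.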

Compound 4, half-maximal inhibitory concentration: > 64000 nM
Compound 4 was reported as a limit (the forecaster's own chance of this, stated with the estimate: 90%); the middle value does not contradict the limit.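

The steps linking compound 4 with compound 1, compound 2 and compound 3 cannot be read in size, because each value is only a limit: the limit of > 64000 nM in this assay, at which 4 of the 4 values shown sit.

The compounds shown leave open whether hydrogen, fluoro or chloro on the aromatic ring makes any difference in this assay.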